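The source may report more compounds than this note shows. Statements on the series, on what has been measured and on what is new or still open speak of the compounds shown alone.

Compound 1 `Cc1ccc(OCCCCCn2ccc(=O)[nH]c2=O)cc1` in an ADME assay on HEL cells (Homo sapiens) for cytotoxicity (a higher number here means that more compound is tolerated, a lower number that less compound is tolerated), gives > 100000 nM, which is a limit of the assay rather than a number.
Compound 2 `CC(C)c1ccc(OCCCCCn2ccc(=O)[nH]c2=O)cc1` gives > 100000 nM, again a limit of the assay.
Compound 3 `O=c1ccn(CCCCCOc2ccc(-c3ccccc3)cc2)c(=O)[nH]1` gives "not determined" (no result reported).

Compound 3 therefore stands without a number of its own in this assay, and the two other values shown are both limits. Compound 4 `N#Cc1ccc(OCCCCCn2ccc(=O)[nH]c2=O)cc1` differs from compound 3 by cyano in place of phenyl on an aromatic carbon. Going by the values given here, the only measured step, a step that the two limits leave unreadable from compound 1 to compound 2, cannot be read in size because both of its values sit at the limit of > 100000 nM in this assay, at which 2 of the 3 values shown sit. Among the compounds with values here, no measured step bears on the change from compound 3 to compound 4, so neither a size nor a direction can be drawn from the data; the expectation rests only on the two limits seen so far. Compound 4 is expected to come out at about 150000 nM, with a range from 50000 nM to 500000 nM.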

Compound 4, half-maximal cytotoxic concentration: 100000 nM
Beside the measured number, compound 4's estimate is 1.5-fold (0.18 log units) above it; the measured number falls inside the stated range.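

In this assay compound 4 gives 100000 nM as a measured number rather than a limit, which makes cyano the only group shown on this aromatic carbon with a readable value, and cyano in place of isopropyl gives a number no higher from compound 2 to compound 4 (the limit leaves the size open), while cyano in place of methyl gives a number no higher from compound 1 to compound 4 (the limit leaves the size open). Neither of these steps can be read in size. Compound 1 and compound 2 each stand at a limit of the assay: the limit of > 100000 nM in this assay, at which 2 of the 4 values shown sit.

Compound 3 has no result, so phenyl cannot be set against cyano at this position. From the compounds shown here alone, how an amine or a carboxylic acid on this aromatic carbon would read in this assay remains open.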